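Difluorophenyl in Place of Dimethoxyphenyl on the Carbonyl

The compounds below may be only part of what the source reports. "The series", "measured", "known", "first", "only" and "open" are said of these compounds alone.

Of the compounds shown here, three built on one shared core have been measured in a functional assay on SK-MEL-2 cells (Homo sapiens) for inhibition, read by sulforhodamine B assay, with a stated time of 48 h; a lower number here means a stronger inhibitor of growth, a higher number a weaker inhibitor of growth. Compound 3 `COc1ccc(C(=O)/C=C/c2cc(-c3cc(OC)c(OC)c(OC)c3)n[nH]2)cc1OC` gives 3510 nM, the lowest of the three numbers, so it is the strongest growth inhibitor of the set. Compound 1 `COc1cc(-c2cc(/C=C/C(=O)c3ccc(N)cc3)[nH]n2)cc(OC)c1OC` gives 7530 nM, and compound 2 `COc1cc(-c2cc(/C=C/C(=O)c3ccc(Cl)c(Cl)c3)[nH]n2)cc(OC)c1OC` gives 34100 nM. The steps between them are a 2.1-fold lower number from compound 1 to compound 3 (0.33 log units; beyond the scatter), a 4.5-fold higher number from compound 1 to compound 2 (0.66 log units; beyond the scatter) and a 9.7-fold lower number from compound 2 to compound 3 (0.99 log units; beyond the scatter); all three concern only the ring attached to the carbonyl carbon.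

Compound 4 `COc1cc(-c2cc(/C=C/C(=O)c3ccc(F)c(F)c3)[nH]n2)cc(OC)c1OC` has not yet been measured. It differs from compound 3 in one place: 3,4-difluorophenyl in place of 3,4-dimethoxyphenyl on a carbonyl carbon. Within the data shown here, the closest guide is a 9.7-fold lower number from compound 2 to compound 3 (0.99 log units; beyond the scatter), the one measured step in which a ring carrying two halogens stands on the carbonyl carbon; the step of a 2.1-fold lower number from compound 1 to compound 3 (0.33 log units; beyond the scatter) shows that any other ring tried so far gives a higher number than compound 3. A rise is therefore expected for compound 4, though likely smaller than the step to compound 2, since fluorine and chlorine are not the same; the expected step is a 3.4-fold higher number from compound 3 to compound 4 (0.53 log units; beyond the scatter). Compound 4 is estimated to give 12000 nM, with a range from 4000 nM to 40000 nM.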

Compound 4, concentration for total growth inhibition: 5890 nM
Beside the measured number, compound 4's estimate is 2.0-fold (0.31 log units) above it, and the stated range covers the measured number.
By their numbers in this assay, from the lowest: compounds 3, 4 and 1 (each within the scatter of the next, the first and the last beyond it); then compound 2.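

In this assay, replacing chlorine with fluorine on the ring at the carbonyl carbon gives a 5.8-fold lower number from compound 2 to compound 4 (0.76 log units; beyond the scatter) and so shows that two halogens on this ring do not always go with the high number of compound 2. The 3,4-difluorophenyl ring cannot be separated from the 3,4-dimethoxyphenyl ring, with a 1.7-fold higher number from compound 3 to compound 4 (0.22 log units; within the scatter) within the scatter, or from the 4-aminophenyl ring, with a 1.3-fold lower number from compound 1 to compound 4 (0.11 log units; within the scatter) also within the scatter, even though compound 1 and compound 3 are separated from each other. Exchanging the 3,4-dimethoxyphenyl ring, with its hydrogen-bond acceptors, for a ring with none therefore brings no change beyond the scatter here.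

Nothing available explains why the fluorine and chlorine rings differ. From the compounds shown here alone, it also remains open how a ring with a single fluorine, or with two methyl groups, would compare on the same carbonyl carbon.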